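A few compounds are considered here, and "the series" means these few. Any claim that something is new, unique, unknown or untested is made for them only; others in the source may bear on it.

Measured so far:
Compound 1 `Cc1cnn(-c2ccc(C)nc2C(=O)N2CC3(CC3)C[C@H]2CNc2ccc(C(F)(F)F)cn2)c1` — in a functional assay on CHO cells for antagonist activity at Orexin/Hypocretin receptor type 1 (Homo sapiens), read by FLIPR and calcium flux (a lower number here means a less potent compound, a higher number a more potent compound, by a factor of ten per unit of this negative logarithm), compound 1 gives 8.9.
Compound 2 `Cc1ccc(-c2ncccn2)c(C(=O)N2CC3(CC3)C[C@H]2CNc2ccc(C(F)(F)F)cn2)n1` — in this assay compound 2 gives 8.4.

For the measured compounds named here, compound 2 holds the lower of the two numbers, separated from compound 1 by the step of a number 0.50 log units lower from compound 1 to compound 2 (beyond the scatter), which is the only measured step in this set.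

Compound 3 `O=C(c1nc(C(F)(F)F)ccc1-c1ncccn1)N1CC2(CC2)C[C@H]1CNc1ccc(C(F)(F)F)cn1` has not yet been measured. It differs from compound 2 in a single place: trifluoromethyl in place of methyl on an aromatic carbon. Going by the values given here, the one measured step, from compound 1 to compound 2, exchanges one ring for another and leaves the methyl untouched, so no measured step bears directly on the change from compound 2 to compound 3. The data offer no guide to the direction of this exchange, and the expectation is therefore a step of a number 0.10 log units lower from compound 2 to compound 3 (within the scatter) in this assay, that is, nothing clearly beyond the scatter, with a wide margin on either side. Compound 3 is accordingly estimated to give about 8.3 in this assay, within a range from 7.6 to 9.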

Compound 3, negative logarithm of the antagonist equilibrium constant: 6.7
Estimate against measurement, compound 3: 1.60 log units above, and the stated range ends above it.
By their numbers in this assay, from the lowest: compound 3; then compound 2; then compound 1.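

In this assay, the aromatic carbon next to the ring nitrogen and para to a pyrimidin-2-yl group proves highly sensitive to what it carries: exchanging methyl for trifluoromethyl there gives a number 1.70 log units lower from compound 2 to compound 3 (beyond the scatter), a large step. The earlier ring exchange, a number 0.50 log units lower from compound 1 to compound 2 (beyond the scatter), was only modest, so in this small set a change in this single substituent counts for more than the change of one aromatic ring for another. Nothing available explains why trifluoromethyl is so much less well tolerated than methyl here.

The compounds shown leave open whether the fall belongs to trifluoromethyl alone or extends to other groups on this carbon, since a hydrogen, a chlorine, an ethyl or a methoxy group could fall nearer to either methyl or trifluoromethyl in this series. They also leave open whether trifluoromethyl would cost as much with the 4-methyl-1H-pyrazol-1-yl group of compound 1 in place of the pyrimidin-2-yl group, as the step has been read only with the latter.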